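Swapping nitro for cyano on compound 3

This account rests on a few compounds, and the source may have more. Where it says the series, first, only, none or still open, it means among the compounds named here.

Compound 3 `O=C(c1ccc([N+](=O)[O-])cc1)N1CCC(n2cncc2-c2ccc(OS(=O)(=O)c3cccc4cnccc34)cc2)CC1` gives the lowest number of the three in an assay on HEK293 cells for antagonist activity at P2X purinoceptor 7 (Homo sapiens), read by fluorescence, with a stated time of 2 h (on this read-out higher numbers stand for weaker inhibition and lower numbers for stronger inhibition), with 1.49 nM. Compound 2 `CS(=O)(=O)c1ccc(C(=O)N2CCC(n3cncc3-c3ccc(OS(=O)(=O)c4cccc5cnccc45)cc3)CC2)cc1` gives 25 nM, and compound 1 `CS(=O)(=O)Oc1ccc(-c2cncn2C2CCN(C(=O)c3ccc(Cl)c(C(F)(F)F)c3)CC2)cc1` gives 1570 nM. Among the compounds with values here, the one measured step, a 17-fold lower number from compound 2 to compound 3 (1.22 log units; beyond the scatter), arose from nitro in place of methylsulfonyl on the same aromatic carbon. Compound 4 `N#Cc1ccc(C(=O)N2CCC(n3cncc3-c3ccc(OS(=O)(=O)c4cccc5cnccc45)cc3)CC2)cc1` carries the change (cyano in place of nitro on an aromatic carbon). Within the data shown here, no measured step exchanges these two particular groups; the earlier step shows only that this carbon can move the number a great deal, so a modest rise, beyond the scatter but far smaller, seems the more likely outcome. Compound 4 is therefore expected to give 4 nM, between 1.5 nM and 12 nM. The expected step is a 2.7-fold higher number from compound 3 to compound 4 (0.43 log units; beyond the scatter).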

Compound 4, half-maximal inhibitory concentration: 269 nM
The estimate for compound 4 lay 67-fold (1.83 log units) below the measured number, and the stated range ends below it.
By their numbers in this assay, from the lowest: compound 3; then compound 2; then compound 4; then compound 1.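

In this assay, the swap at this aromatic carbon, para to a large group, proved far from modest, with a 180-fold higher number from compound 3 to compound 4 (2.26 log units; beyond the scatter). The cyano group also fell behind methylsulfonyl, with an 11-fold higher number from compound 2 to compound 4 (1.03 log units; beyond the scatter), so the three groups order as nitro, methylsulfonyl, cyano, and the size of the group alone does not follow that order, as methylsulfonyl and nitro both exceed cyano in heavy atoms only where counted. Nothing available explains this order.

From the compounds shown here alone, whether a low number at this carbon is peculiar to nitro stays open, as a carboxylic acid, an amine or a methoxy group could sit there instead. Going by these compounds, whether the same order holds on other cores also remains unknown.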